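The source may hold more compounds than are shown below. What is called first, only, known or untested is meant among the compounds shown, and "the series" means these compounds.

Measured in a functional assay on CAL-27 cells (Homo sapiens) for cytotoxicity, read by MTT assay, with a stated time of 72 h; a higher number here means a weaker inhibitor, a lower number a stronger inhibitor:

compound 1, `Cc1cc(C)cc(C(=O)N(CC(=O)NCc2ccccc2)Cc2ccc(C(=O)Nc3cc(-c4ccccc4)ccc3N)cc2)c1` — 8900 nM
compound 2, `Cc1cc(C)cc(C(=O)N(CCCCCC(=O)Nc2ccccc2N)CC(=O)NCc2ccccc2)c1` — 13700 nM
compound 3, `Cc1cc(C)cc(C(=O)N(CC(=O)NCc2ccccc2)Cc2ccc(C(=O)Nc3ccccc3N)cc2)c1` — 1600 nM

Compound 1 carries phenyl in place of hydrogen on an aromatic carbon relative to compound 3, and in this assay this gives a 5.6-fold higher number from compound 3 to compound 1 (0.75 log units; beyond the scatter). Compound 2 and compound 3 differ in their cores; that difference is not broken down here.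

Going by the values given here, compound 4, `Cc1cc(C)cc(C(=O)N(CCCCCC(=O)Nc2cc(-c3ccccc3)ccc2N)CC(=O)NCc2ccccc2)c1`, is the counterpart of compound 2 with phenyl in place of hydrogen on an aromatic carbon, the same change as the one from compound 3 to compound 1, at a place described in the same words.

Among the compounds with values here, for this assay compound 4 is expected to show a 5.1-fold higher number from compound 2 to compound 4 (0.71 log units; beyond the scatter), a step of about the size seen in a 5.6-fold higher number from compound 3 to compound 1 (0.75 log units; beyond the scatter), because the only measured example of this change, a 5.6-fold higher number from compound 3 to compound 1 (0.75 log units; beyond the scatter), went in that direction. Compound 4 is therefore estimated at 70000 nM, between 25000 nM and 200000 nM.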

Compound 4, half-maximal inhibitory concentration: 18900 nM
Compound 4: the middle estimate sits 3.7-fold (0.57 log units) above what was measured; measured number below the stated range.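

In this assay, phenyl in place of hydrogen on an aromatic carbon gives a 1.4-fold higher number from compound 2 to compound 4 (0.14 log units; within the scatter), so the larger step seen on the other core does not carry over at its size. The two steps set side by side read: the same change on two cores in this assay, a 5.6-fold higher number (0.75 log units; beyond the scatter) from compound 3 to compound 1 and a 1.4-fold higher number (0.14 log units; within the scatter) from compound 2 to compound 4, 4.0-fold (0.61 log units) apart, beyond the scatter of two such steps. This shows that the size of the step differs between these two cores, but two cores give no rule for any other core and do not show what causes the gap.

Still open, as far as these compounds go, is whether a smaller group at the same place, such as methyl or a fluorine atom, would also give steps that differ between the two cores. From the compounds shown here alone, a longer or shorter chain in the core of compound 2 remains open too.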